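The source may hold more compounds than are shown below. What is called first, only, known or untested is meant among the compounds shown, and "the series" means these compounds.

Compounds measured in a functional assay on K562 cells (Homo sapiens) for cytotoxicity, read by MTT assay, with a stated time of 72 h; on this read-out lower numbers stand for stronger inhibition and higher numbers for weaker inhibition:

- Compound 1 `COc1ccc(/C=C2\CC[C@H]3C(C)(C)CCC[C@]3(C)[C@H]2CCC(C)CC(=O)O)cc1`: > 200000 nM, a limit of the assay and not a number
- Compound 2 `CC(CC[C@H]1/C(=C/c2ccc([N+](=O)[O-])cc2)CC[C@H]2C(C)(C)CCC[C@]12C)CC(=O)O`: 169000 nM

Among the compounds with values here, compound 2, at 169000 nM, holds the only actual number. For compound 1 the reading stands at the limit of > 200000 nM in this assay, at which 1 of the 2 values shown sits.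

Compound 3 `CC(CC[C@H]1/C(=C/c2ccc(F)cc2)CC[C@H]2C(C)(C)CCC[C@]12C)CC(=O)O` has not yet been measured. It differs from compound 2 by a single exchange, fluoro in place of nitro on an aromatic carbon, so that 4-nitrophenyl becomes 4-fluorophenyl.

Within the data shown here, only one measured step bears on this, a change of the group on that same aromatic carbon, with nitro in place of methoxy: an at least 1.1-fold lower number from compound 1 to compound 2 (0.07 log units; that floor lies within the scatter). Since one end of that step is a limit, it gives a floor and not a true size. It offers no ground for expecting a real shift, so no change beyond the scatter is expected in this assay, and the assay may again report only a limit. The expected step is a 1.0-fold higher number from compound 2 to compound 3 (0.00 log units; within the scatter). The estimate for compound 3 is 170000 nM, with an expected range of 90000 nM to 260000 nM.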

Compound 3, half-maximal inhibitory concentration: > 200000 nM
Compound 3: no number, only a limit (the forecaster's own chance of this, stated with the estimate: 40%); at least 1.1-fold (0.07 log units) between middle value and limit.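

In this assay compound 3 gives > 200000 nM, a limit and not a number. With 4-fluorophenyl in place of 4-nitrophenyl, the series now has a second compound at that limit: the limit of > 200000 nM in this assay, at which 2 of the 3 values shown sit.

The exchange of nitro for fluoro gives an at least 1.1-fold higher number from compound 2 to compound 3 (0.07 log units; that floor lies within the scatter), so neither change on this aromatic carbon has produced a step shown to lie beyond the scatter, and the step between compound 1 and compound 3 cannot be read.

The compounds shown leave open whether an amine or a hydroxyl on that same aromatic carbon would give a clearly lower number than compound 2 does. They also leave open whether a change elsewhere in the molecule, such as an amide or a methyl ester in place of the carboxylic acid, would bring a real shift in this assay.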